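The source may report more compounds than this note shows. Statements on the series, on what has been measured and on what is new or still open speak of the compounds shown alone.

Measured compounds:
Compound 1, `COc1cc(NC(C)CCCNC(=O)Nc2ccc(F)cc2)c2ncccc2c1`: 18000 nM
Compound 2, `COc1cc(NC(C)CCCNC(=O)Nc2cc(C(F)(F)F)cc(C(F)(F)F)c2)c2ncccc2c1`: 3500 nM
Compound 3, `COc1cc(NC(C)CCCNC(=O)NNC(=O)Nc2cc(C(F)(F)F)cc(C(F)(F)F)c2)c2ncccc2c1`: 18000 nM

The three compounds share a core and differ in the aryl part of the urea. In a functional assay on L1210 cells (Mus musculus) for inhibition, read by MTT assay, with a stated time of 72 h (on this read-out lower numbers stand for stronger inhibition and higher numbers for weaker inhibition), compound 1 gives 18000 nM, which is level, at the digits given, with compound 3 at 18000 nM; the two lie within the scatter of each other and together stand at the high end of the three numbers. Compound 2, with two trifluoromethyl groups on the aryl ring, gives 3500 nM, a clearly lower number than compound 1 that lies beyond the scatter.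

Compound 4, `COc1cc(NC(C)CCCNC(=O)Nc2ccc(O)cc2)c2ncccc2c1`, has not yet been measured in this assay. Compared with compound 1 it differs in one place: hydroxy in place of fluoro on an aromatic carbon. Among the measured compounds shown here, no measured pair shows this exchange, so its effect can only be guessed from the single comparison that a change on the aryl ring can move the number, as compound 2 shows. A hydroxy in place of fluoro is a small change in size, and the expected step from compound 1 to compound 4 is a 1.1-fold higher number from compound 1 to compound 4 (0.05 log units; within the scatter), small and within or only just beyond the scatter, with no strong lean in either direction. Compound 4 is therefore estimated at 20000 nM, with a range from 7000 nM to 60000 nM.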

Compound 4, half-maximal inhibitory concentration: 21000 nM
Estimate against measurement, compound 4: 1.1-fold (0.02 log units) below; the measured number falls inside the stated range.
By their numbers in this assay, from the lowest: compound 2; then compounds 1, 3 and 4 (each within the scatter of the next).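

Among the compounds shown here, the exchange of fluoro for hydroxy on this aromatic carbon, para to a large group, gives the first reading of a single change: in this assay the move from 4-fluorophenyl to 4-hydroxyphenyl amounts to a 1.2-fold higher number from compound 1 to compound 4 (0.07 log units; within the scatter) and so leaves the two compounds indistinguishable. The earlier compounds shown here offered no pair differing in one place, so they could only hint that the aryl part matters, whereas this pair shows that at this position a hydroxy, with its hydrogen-bond donor and acceptor, and a fluoro, with neither, give numbers that cannot be told apart. Nothing among the data shown explains this outcome.

Going by these compounds, whether the position would respond the same way to other groups, such as an amine, a carboxylic acid or a longer chain, remains open, as this one exchange samples only two small substituents. On these data alone, it is also open whether hydroxy in place of fluoro would read the same on the aryl ring with two trifluoromethyl groups, or with the extended linker of compound 3.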